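A few compounds are considered here, and "the series" means these few. Any claim that something is new, unique, unknown or untested is made for them only; others in the source may bear on it.

Measured in a functional assay on A2780 cells (Homo sapiens) for cytotoxicity; a higher number here means a weaker inhibitor, a lower number a stronger inhibitor:
- compound 1 `CC(C)(C)c1cnc(CSc2cnc(Nc3ccccn3)s2)o1`: 10 nM
- compound 2 `CC(C)(C)c1cnc(CSc2cnc(Nc3ccc(S(=O)(=O)NCCO)cc3)s2)o1`: 69 nM
- compound 3 `CC(C)(C)c1cnc(CSc2cnc(Nc3ccccc3)s2)o1`: 140 nM

Compound 3 has the highest number of the three and is the weakest inhibitor in this set. Its closest neighbour is compound 2, and compound 1 lies furthest from it.

Compound 4 `CC(C)(C)c1cnc(CSc2cnc(Nc3cccnc3)s2)o1` has pyridin-3-yl in place of phenyl on a nitrogen on an aromatic ring.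

Within the data shown here, two measured steps bear on this change. The closer one is large: a 14-fold higher number from compound 1 to compound 3 (1.15 log units; beyond the scatter). It swaps phenyl and pyridin-2-yl at the same place, with compound 3 on the phenyl side and the lower number on the pyridine side. However, compound 1 carries pyridin-2-yl, not pyridin-3-yl, and no measured compound shows how much of that gap carries over to the other pyridine. The second step is modest: a 2.0-fold higher number from compound 2 to compound 3 (0.31 log units; beyond the scatter). Among the measured compounds shown here, it shows only that compound 3 also has the higher number when the aromatic ring of compound 2 loses its (2-hydroxyethyl)sulfamoyl group.

A step to a lower number is therefore expected, smaller than the large one: a 2.8-fold lower number from compound 3 to compound 4 (0.45 log units; beyond the scatter). The uncertainty is wide, and no change beyond the scatter remains possible. In this assay the estimate for compound 4 is 50 nM, with an expected range of 15 nM to 150 nM.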

Compound 4, half-maximal inhibitory concentration: 50 nM
Beside the measured number, compound 4's estimate shows no gap at the digits printed; low and high end bracket the measured number.
By their numbers in this assay, from the lowest: compound 1; then compounds 4 and 2 (each within the scatter of the next); then compound 3.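

In this assay, the lower number seen on the pyridine side is not confined to pyridin-2-yl: pyridin-3-yl on the same nitrogen also improves on phenyl, with a 2.8-fold lower number from compound 3 to compound 4 (0.45 log units; beyond the scatter). The two pyridines are not interchangeable at this place, however, as the change from pyridin-2-yl to pyridin-3-yl gives a 5.0-fold higher number from compound 1 to compound 4 (0.70 log units; beyond the scatter), so the identity of the pyridine matters as well as the presence of a ring nitrogen. Nothing available explains either step or the difference between the two pyridines.

Still open, on these data alone, is how pyridin-4-yl would compare with the two pyridines and with phenyl, and whether a small substituent such as a methyl or an amine on the pyridin-2-yl ring would keep the number of compound 1. Among these compounds, it is also unclear whether the (2-hydroxyethyl)sulfamoyl group, so far seen only on a phenyl ring, would lower the number further on a pyridine ring or whether its step and the pyridine step would fail to add up.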